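A few compounds are considered here, and "the series" means these few. Any claim that something is new, unique, unknown or untested is made for them only; others in the source may bear on it.

Working notes on the series around the core of compound 1 `CN1CCC[C@H](OCc2cc(Cl)cc(Cl)c2)[C@@H]1c1ccccc1`.

In an assay on isolated protein for activation of cGMP-dependent protein kinase 1 (Homo sapiens), read by ADP-Glo, with stated times of 120 min and 40 min (a lower number here means that less compound is needed, a higher number that more compound is needed for the effect), compound 1 gives only a limit, > 200000 nM, so no number stands for it; it sits at the limit of > 200000 nM in this assay, at which 1 of the 2 values shown sits. Compound 2 `OC[C@@H](O[C@H]1CCCN(Cc2cccc3nonc23)[C@H]1c1ccccc1)c1cc(Cl)cc(Cl)c1` carries an arylmethyl on the ring nitrogen together with further changes elsewhere, and in this assay compound 2 gives 8000 nM. Among the measured compounds shown here, no step between two measured compounds differing in one place is recorded, so the two values show only that an arylmethyl-bearing compound reaches a number where compound 1 does not.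

Compound 3 `Cn1ccnc1CN1CCC[C@H](OCc2cc(Cl)cc(Cl)c2)[C@@H]1c1ccccc1` is not yet measured and differs from compound 1 in one place: 1-methyl-1H-imidazol-2-yl in place of hydrogen on a saturated chain carbon bound to an amine nitrogen in a ring. Since compound 2 gives 8000 nM with an aromatic ring on that same ring nitrogen, a step toward less compound is expected from compound 1 to compound 3, estimated as an at least 3.3-fold lower number from compound 1 to compound 3 (0.52 log units; beyond the scatter), though compound 2 differs in more than this one place. For compound 3 a value of 60000 nM is expected, within 10000 nM to 200000 nM.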

Compound 3, half-maximal effective concentration: 165000 nM
Beside the measured number, compound 3's estimate is 2.8-fold (0.44 log units) below it; low and high end bracket the measured number.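

With 1-methyl-1H-imidazol-2-yl in place of hydrogen on a saturated chain carbon bound to an amine nitrogen in a ring, the series now has its first one-place step in this assay and it reads an at least 1.2-fold lower number from compound 1 to compound 3 (0.08 log units; that floor lies within the scatter). This floor alone does not establish that the change lowers the number, and it does not rule out a larger step. The value of compound 1 is a limit and not a number, which leaves the true size of the step open: the limit of > 200000 nM in this assay, at which 1 of the 3 values shown sits.

Among the compounds shown here, compound 2 differs from compound 3 in more than one place, so no step between them can be read. Open also is whether a phenyl or a carboxylic acid at this same place would give a lower number than 1-methyl-1H-imidazol-2-yl.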